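From cyclohexyl to cyclopropyl on the sulfonyl chain

A few compounds are considered here, and "the series" means these few. Any claim that something is new, unique, unknown or untested is made for them only; others in the source may bear on it.

Within the data shown here, in a functional assay, read by fluorescence and spectrophotometry, with a stated time of 1 h (on this read-out higher numbers stand for an effect only at larger amounts of compound and lower numbers for an effect already at smaller amounts), compound 1 `O=S(=O)(/C=C/c1ccc(O)c(O)c1)CCC1CCCCC1` gives 9800 nM and compound 2 `O=S(=O)(/C=C/c1ccc(O)c(O)c1)CC1CCCCC1` gives 7500 nM on the only two numbers available so far. Compound 2 therefore stands within the scatter of compound 1, and the data do not separate them. Among the measured compounds shown here, the one measured step is a 1.3-fold lower number from compound 1 to compound 2 (0.12 log units; within the scatter) and it comes with cyclohexyl in place of cyclohexylmethyl on a saturated chain carbon bound to a sulfonyl sulfur.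

Compound 3 `O=S(=O)(/C=C/c1ccc(O)c(O)c1)CC1CC1` has not yet been measured. It differs from compound 2 at a single place, cyclopropyl in place of cyclohexyl on a saturated chain carbon bound to a sulfonyl sulfur with cyclopropyl in place of cyclohexyl on a saturated chain carbon bound to a sulfonyl sulfur. For the measured compounds named here, the step from compound 1 is the only measured guide, and it changes the group in a different way, since no three-membered ring has yet been tested. With that one step as small as a 1.3-fold lower number from compound 1 to compound 2 (0.12 log units; within the scatter) no shift beyond the scatter is expected, although the range must stay wide. The expected change is a 1.1-fold higher number from compound 2 to compound 3 (0.05 log units; within the scatter) in this assay on this estimate. Compound 3 is expected at 8500 nM with an estimated range from 3500 nM to 20000 nM once measured.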

Compound 3, half-maximal effective concentration: 10500 nM
The estimate for compound 3 lay 1.2-fold (0.09 log units) below the measured number; the range from low to high includes it.
By their numbers in this assay, from the lowest: compounds 2, 1 and 3 (each within the scatter of the next).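

In this assay, the step from a cyclohexyl group of 6 heavy atoms to a cyclopropyl group of 3 heavy atoms, on a saturated chain carbon bound to a sulfonyl sulfur, gives a 1.4-fold higher number from compound 2 to compound 3 (0.15 log units; within the scatter), so this change in ring size and atom count does not separate the two compounds on this read-out. The wider exchange of cyclohexylmethyl for cyclopropyl at the same place gives a 1.1-fold higher number from compound 1 to compound 3 (0.03 log units; within the scatter), which means that all three groups now tested there, including the first three-membered ring, remain within the scatter of one another and that none of the three can be ranked above the others. No independent measurement is available that could account for this flat result.

From the compounds shown here alone, it remains open whether the numbers would also stay together with a group of another kind at this place, such as an amine, a carboxylic acid, a phenyl ring or a longer straight chain. The three compounds also leave open whether any change to the shared core would produce a step beyond the scatter.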